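Half-life notes on a chain change from compound 2

The compounds below may be only part of what the source reports. "The series", "measured", "known", "first", "only" and "open" are said of these compounds alone.

Three compounds sharing one core, each carrying a long chain, have been read so far in an ADME assay on the whole organism (plasma) for pharmacokinetics, with Homo sapiens as the target (on this read-out higher numbers stand for a longer-lived compound and lower numbers for a shorter-lived compound), on this series. Among the measured compounds shown here, compound 2 (`CCCCCCCCCCCCCCCC(=O)OCC1C=CC(n2cc(C)c(=O)[nH]c2=O)O1`) gives 4 h in this assay and holds the only true number. Compound 1 (`CCCCCCCCCCCCCCCCOP(=O)(O)OCC1C=CC(n2cc(C)c(=O)[nH]c2=O)O1`) reads > 24 h as its result, which is a limit of the assay and not a number. Compound 3 (`CCCCCCCCCCCCCCCCNC(=O)OCC1C=CC(n2cc(C)c(=O)[nH]c2=O)O1`) reads > 24 h as its result, again a limit and not a number.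

Compound 4 (`C/C=C/C/C=C/C/C=C/CCCCCCCC(=O)OCC1C=CC(n2cc(C)c(=O)[nH]c2=O)O1`) is still unmeasured. Its difference from compound 2 is a group of 9 heavy atoms (9 carbon; no ring) in place of a group of 8 heavy atoms (8 carbon; no ring), on a saturated chain carbon, seven bonds along the chain from a carbonyl carbon and the entering group carries 3 double bonds outside aromatic rings, while the link to the shared core stays as it is in compound 2. For the measured compounds named here, no measured pair shows what a chain change of this kind does, so the expectation rests on compound 2 at 4 h as the single anchor. The expected size is a 1.1-fold lower number from compound 2 to compound 4 (0.06 log units; within the scatter) as an estimate, with no firm direction and nothing expected beyond the usual scatter. In this assay the expected value for compound 4 is 3.5 h within an estimated range of 1.5 h to 8 h as the working figure.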

Compound 4, half-life: 1 h
Beside the measured number, compound 4's estimate is 3.5-fold (0.54 log units) above it, outside the stated range (below it).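

Read in this assay, the change of octyl for the entering group of 9 heavy atoms, on a saturated chain carbon, seven bonds along the chain from a carbonyl carbon, gives a 4.0-fold lower number from compound 2 to compound 4 (0.60 log units; beyond the scatter). Among the compounds shown here, this is the first pair that can be read as a step, and it shows that the half-life responds to a change far along the chain while the link to the shared core stays as it is in compound 2. The step is beyond the usual scatter but modest, and it comes from one pair, so it holds for this position and this change only.

The entering group brings both 3 double bonds and one further carbon, so this step does not separate the two, and a saturated nonyl chain on the same link would be the group that bears on that question. How such a chain change behaves on the links of compound 1 and compound 3 stays open, and no step to either of those compounds can be read: the limit of > 24 h in this assay, at which 2 of the 4 values shown sit.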